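A Morpholine Substituent Replaces the Pyrazole of Compound 2

The compounds below may be only part of what the source reports. "The series", "measured", "known", "first", "only" and "open" are said of these compounds alone.

Three ureas sharing one core have been measured in a functional assay on CHO cells for agonist activity at sphingosine 1-phosphate receptor 2 (Homo sapiens), read by fluorescence and calcium flux, with a stated time of 3 min; on this read-out lower numbers stand for stronger inhibition and higher numbers for weaker inhibition. Compound 1 `Cc1cc(CNC(=O)Nc2cc(Cl)nc(Cl)c2)ncc1-c1cn(C)nc1C` gives 3500 nM, compound 2 `CCOc1cc(NC(=O)NCc2cc(C)c(-c3cn(C)nc3C)cn2)cc(Cl)n1` gives 4700 nM, and compound 3 `Cc1cc(CNC(=O)Nc2cc(Cl)cc(Cl)c2)ncc1-c1cn(C)nc1C` gives 3200 nM. Compound 2 carries the highest of the three numbers, yet the step of a 1.3-fold higher number from compound 1 to compound 2 (0.13 log units; within the scatter) lies within the scatter, and the values of compound 2 and compound 3 also sit within the scatter of each other, so no ordering among the three can be claimed.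

The next compound, compound 4 `CCOc1cc(NC(=O)NCc2cc(C)c(N3CC(C)OC(C)C3)cn2)cc(Cl)n1`, differs from compound 2 in one place: 2,6-dimethylmorpholin-4-yl in place of 1,3-dimethyl-1H-pyrazol-4-yl on an aromatic carbon. Neither measured step touches this position. The step of a 1.3-fold higher number from compound 1 to compound 2 (0.13 log units; within the scatter) concerned ethoxy in place of chloro, and the step of a 1.1-fold lower number from compound 1 to compound 3 (0.04 log units; within the scatter) concerned the aryl group on the urea nitrogen; both were within the scatter and both lie elsewhere on the molecule. Among the compounds with values here, the data therefore give no direct precedent for exchanging the pyrazolyl group for the morpholinyl group.

With nothing pointing either way, compound 4 is estimated at 5000 nM in this assay, within a deliberately wide range from 1500 nM to 20000 nM. That estimate corresponds to an expected step of a 1.1-fold higher number from compound 2 to compound 4 (0.03 log units; within the scatter), which is expected to stay within the scatter.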

Compound 4, half-maximal inhibitory concentration: 4200 nM
Compound 4: the middle estimate sits 1.2-fold (0.08 log units) above what was measured, within the range that was stated.
By their numbers in this assay, from the lowest: compounds 3, 1, 4 and 2 (each within the scatter of the next).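

In this assay, within the data shown here, the exchange on the aromatic carbon ortho to a methyl group gives a 1.1-fold lower number from compound 2 to compound 4 (0.05 log units; within the scatter), which is the first reading at this position. With the ethoxy group on the urea's aryl ring held constant, the aromatic five-membered ring of 1,3-dimethyl-1H-pyrazol-4-yl and the non-aromatic six-membered ring of 2,6-dimethylmorpholin-4-yl cannot be told apart in this read-out, so the aromatic ring is shown not to be needed here for a number of this size, at least in this one pair. No measurement is available that would account for this result.

The pair leaves open whether the same exchange would behave alike on the chloro compound 1 or on the 3,5-dichlorophenyl compound 3, since it has been read only on the ethoxy urea. It also leaves open whether another group at this position, such as a morpholin-4-yl ring without its two methyl groups, a piperidin-1-yl ring, a primary amine or a carboxylic acid, would produce a step beyond the scatter.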